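The compounds below may be only part of what the source reports. "The series", "measured", "known", "first", "only" and "open" are said of these compounds alone.

Within the data shown here, in an ADME assay on cells (Hepatocyte, Rattus norvegicus, strain Wistar) for pharmacokinetics, read by LC-MS, with a stated time of 90 min, tested at 1 uM (on this read-out higher numbers stand for fast clearance and lower numbers for slow clearance), three amides on the shared core have numbers so far. Compound 1 (`COc1cc(C(=O)N2CCCC2(C)C)cc2nc(NCc3cccc(Cl)c3)oc12`) gives 58.3 mL/min/kg, compound 2 (`COc1cc(C(=O)N2CCC(O)CC2)cc2nc(NCc3cccc(Cl)c3)oc12`) gives 21.7 mL/min/kg, and compound 3 (`COc1cc(C(=O)N2CC(C)C(O)CC2C)cc2nc(NCc3cccc(Cl)c3)oc12`) gives 56.7 mL/min/kg. Compound 3 lies in the fast-clearance part of this small set, alongside compound 1 and apart from compound 2. The data show a 1.0-fold lower number from compound 1 to compound 3 (0.01 log units; within the scatter), and also a 2.6-fold higher number from compound 2 to compound 3 (0.42 log units; beyond the scatter).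

Compound 4 (`COc1cc(C(=O)N2CC(C)C(O)CC2CCO)cc2nc(NCc3cccc(Cl)c3)oc12`) differs from compound 3 by hydroxymethyl in place of hydrogen on a saturated chain carbon bound to a saturated ring carbon, which turns methyl into 2-hydroxyethyl. Among the measured compounds shown here, no measured step makes this exact change, so the evidence is indirect. For the measured compounds named here, the steps that bear on it are a 2.7-fold lower number from compound 1 to compound 2 (0.43 log units; beyond the scatter) and a 2.6-fold higher number from compound 2 to compound 3 (0.42 log units; beyond the scatter), both modest and both involving a hydroxylated amide. On that basis, a lowering no larger than these steps is expected in this assay, and it may not clear the scatter. The expected change is a 1.8-fold lower number from compound 3 to compound 4 (0.25 log units; within the scatter). For compound 4 the estimated clearance is 32 mL/min/kg, with an expected range of 16 mL/min/kg to 60 mL/min/kg.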

Compound 4, clearance: 4.5 mL/min/kg
The estimate for compound 4 lay 7.1-fold (0.85 log units) above the measured number; measured number below the stated range.
By their numbers in this assay, from the lowest: compound 4; then compound 2; then compounds 3 and 1 (each within the scatter of the next).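

Hydroxymethyl in place of hydrogen on a saturated chain carbon bound to a saturated ring carbon, which turns methyl into 2-hydroxyethyl, is a far stronger change in this assay than any earlier step showed, with a 13-fold lower number from compound 3 to compound 4 (1.10 log units; beyond the scatter). The 2-hydroxyethyl amide also stands clear of both earlier amide types, with a 4.8-fold lower number from compound 2 to compound 4 (0.68 log units; beyond the scatter) and a 13-fold lower number from compound 1 to compound 4 (1.11 log units; beyond the scatter), so the 4-hydroxy group of compound 3 does not by itself give a low number in this set. No measured property in these data accounts for the drop.

On these data alone, whether the hydroxyl or the added chain length carries the change stays open; ethyl, 2-methoxyethyl, 3-hydroxypropyl, an amine or a carboxylic acid in place of the 2-hydroxyethyl would separate these. As far as these compounds go, whether the change carries over to other amides on the shared core also stays open.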